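Ethoxycarbonyl to Hydroxymethyl: an Expected Cytotoxicity Reading

The source may report more compounds than this note shows. Statements on the series, on what has been measured and on what is new or still open speak of the compounds shown alone.

Three compounds sharing one core have been run through an ADME assay on HeLa cells (Homo sapiens) for cytotoxicity, read by sulforhodamine B assay, with a stated time of 48 h, tested at 10 uM; a lower number here means less inhibition, a higher number more inhibition at the concentration tested (going by the name of the read-out). Compound 1 `CCCCCCc1cn(C(c2ccccc2)c2cc3cc(Br)ccc3nc2OC)nn1` gives -0.97%. Compound 2 `CCCCc1cn(C(c2ccccc2)c2cc3cc(Br)ccc3nc2OC)nn1` gives -2.87%, and the step of a number 1.9 percentage points lower from compound 1 to compound 2 (within the scatter). Compound 3 `CCOC(=O)c1cn(C(c2ccccc2)c2cc3cc(Br)ccc3nc2OC)nn1` gives -3.67%, the lowest of the three readings, with the steps of a number 2.7 percentage points lower from compound 1 to compound 3 (within the scatter) and a number 0.8 percentage points lower from compound 2 to compound 3 (within the scatter). None of the three compounds inhibits the cells to a degree that rises out of the scatter, so no order among them can be claimed.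

Compound 4 `COc1nc2ccc(Br)cc2cc1C(c1ccccc1)n1cc(CO)nn1` differs from compound 3 by hydroxymethyl in place of ethoxycarbonyl on an aromatic carbon. The steps that touch the same position are those from compound 1 and compound 2 to compound 3, and both lie within the scatter, so the group on that aromatic carbon has so far not moved the reading. Going by the values given here, nothing among the measured compounds points to a different outcome for hydroxymethyl, and a step beyond the scatter is not expected. The expected step is a number 1.7 percentage points higher from compound 3 to compound 4 (within the scatter). Compound 4 is therefore estimated to give -2% in this assay, with a range from -12% to 8%.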

Compound 4, a percentage reported as inhibition, at one concentration (the size of the read-out at that concentration, not a potency): 0.25%
For compound 4 the middle estimate is 2.3 percentage points below the measured one, and the stated range covers the measured number.
By their numbers in this assay, from the lowest: compounds 3, 2, 1 and 4 (each within the scatter of the next).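

In this assay, replacing ethoxycarbonyl (5 heavy atoms, 0 hydrogen-bond donors) with the smaller hydroxymethyl (2 heavy atoms, 1 hydrogen-bond donor) on this aromatic carbon of the five-membered aromatic ring with 3 nitrogen gives a number 3.9 percentage points higher from compound 3 to compound 4 (within the scatter), so this change of size and donor count leaves the reading within the scatter. The same holds when hydroxymethyl is set against the alkyl chains, with a number 3.1 percentage points higher from compound 2 to compound 4 (within the scatter) and a number 1.2 percentage points higher from compound 1 to compound 4 (within the scatter), which extends the flat picture at this position from hexyl, butyl and ethoxycarbonyl to a group ending in hydroxy. No measurement shown here offers an explanation for the readings of these four compounds.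

As far as these compounds go, whether an aminomethyl group or a carboxylic acid on the same aromatic carbon would also stay within the scatter remains open. So does whether replacing the bromine on the shared core, or the methoxy group beside which these triazole substituents were varied only at a distance, would move the reading at all.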